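Benzyl-substituted adenosines against melanoma cell proliferation

The compounds below may be only part of what the source reports. "The series", "measured", "known", "first", "only" and "open" are said of these compounds alone.

Compound 3 `COc1cccc(CNc2ncnc3c2ncn3[C@@H]2O[C@H](CO)[C@@H](O)[C@H]2O)c1OC` carries the 2,3-dimethoxyphenyl group; in a functional assay on G-361 cells (Homo sapiens) for antiproliferative activity, with a stated time of 72 h (a lower number here means a stronger inhibitor, a higher number a weaker inhibitor), compound 3 gives "not determined" (no result reported), so no number places it within the series. Compound 2 `OC[C@H]1O[C@@H](n2cnc3c(NCc4ccc(Cl)c(Cl)c4)ncnc32)[C@H](O)[C@@H]1O` gives 145000 nM in this assay. Compound 1 `OC[C@H]1O[C@@H](n2cnc3c(NCc4ccc(Cl)cc4)ncnc32)[C@H](O)[C@@H]1O` returns only a limit in this assay, > 166000 nM. Within the data shown here, the single measured step, an at least 1.1-fold lower number from compound 1 to compound 2 (0.05 log units; that floor lies within the scatter), stays within scatter and concerns a different position of the molecule. Compound 4 `OC[C@H]1O[C@@H](n2cnc3c(NCc4cc(O)cc(O)c4)ncnc32)[C@H](O)[C@@H]1O` differs from compound 3 by 3,5-dihydroxyphenyl in place of 2,3-dimethoxyphenyl on a saturated chain carbon bound to a nitrogen on an aromatic ring. Among the measured compounds shown here, no measured step touches this change, so no direction can be read from the series; the only guide is that the measured compounds sit near the weak end of the tested range. Compound 4 is therefore expected to give about 150000 nM in this assay, within 50000 nM to 300000 nM.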

Compound 4, half-maximal inhibitory concentration: > 166000 nM
Compound 4 ended at the assay's limit; the forecaster's own chance of this, stated with the estimate: 50%; at least 1.1-fold (0.04 log units) between middle value and limit.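

Compound 4 stands at a limit of this assay, not at a number: the limit of > 166000 nM in this assay, at which 2 of the 4 values shown sit.

Replacing 3,4-dichlorophenyl with 3,5-dihydroxyphenyl on the saturated chain carbon gives an at least 1.1-fold higher number from compound 2 to compound 4 (0.05 log units; that floor lies within the scatter), so this change brings no readable gain in activity. The step from compound 1 to compound 4 cannot be read, since both values are limits.

On these data alone, what an amine or a carboxylic acid on the phenyl ring, or a longer chain at this carbon, would do in this assay stays open. As far as these compounds go, the standing of compound 3, with its 2,3-dimethoxyphenyl group, also stays open.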